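Half-life in the series: variation at one aromatic carbon

A few compounds are considered here, and "the series" means these few. Any claim that something is new, unique, unknown or untested is made for them only; others in the source may bear on it.

In an ADME assay on the whole organism (Macaca fascicularis) for metabolic stability, read by LC-MS, using cassette dosing, at a dose of 1 mg/kg by the oral route (a higher number here means that the compound lasts longer, a lower number that the compound disappears faster), compound 1 `CCCCN(c1nc2c(NS(C)(=O)=O)cccc2o1)[C@H](C)c1ccc(-c2ccccc2-c2nnn[nH]2)cc1` gives 4.7 h, and compound 2 `CCCCN(c1nc2c(-c3nccn3C)cccc2o1)[C@H](C)c1ccc(-c2ccccc2-c2nnn[nH]2)cc1` gives 3.9 h. The two differ only at one aromatic carbon, and the step of a 1.2-fold lower number from compound 1 to compound 2 (0.08 log units; within the scatter) stays within the scatter. Among the measured compounds shown here, compound 2 thus holds the lowest of the two numbers so far, with compound 1 as its only neighbour, separated by a gap that the usual scatter covers.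

Compound 3 `CCCCN(c1nc2c(CO)cccc2o1)[C@H](C)c1ccc(-c2ccccc2-c2nnn[nH]2)cc1` continues from compound 2 by the change (hydroxymethyl in place of 1-methyl-1H-imidazol-2-yl on an aromatic carbon). Hydroxymethyl appears in no measured pair, so the only step that bears on the same position is the one from compound 1 to compound 2, and that step did not move the half-life beyond the scatter. On that basis no step beyond the scatter is expected in this assay for compound 3, although the step rests on a single comparison at this position and a wider range is allowed for the unmeasured group.

For compound 3 the half-life is estimated at 3.3 h, between 1.4 h and 7.5 h, an expected step of a 1.2-fold lower number from compound 2 to compound 3 (0.07 log units; within the scatter).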

Compound 3, half-life: 1.6 h
Compound 3: middle estimate off by 2.1-fold (0.31 log units), on the high side; low and high end bracket the measured number.
By their numbers in this assay, from the lowest: compound 3; then compounds 2 and 1 (each within the scatter of the next).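

The position proves sensitive to this change in this assay: hydroxymethyl in place of 1-methyl-1H-imidazol-2-yl gives a 2.4-fold lower number from compound 2 to compound 3 (0.39 log units; beyond the scatter), and hydroxymethyl in place of methanesulfonamido gives a 2.9-fold lower number from compound 1 to compound 3 (0.47 log units; beyond the scatter), whereas the exchange between the two earlier groups stayed within the scatter. Among the three groups, hydroxymethyl alone stands apart, with both of its steps modest but beyond the scatter, so the flat picture given by the first pair does not hold for the whole position. The change from the imidazolyl group removes a five-membered aromatic ring and brings in a hydrogen-bond donor, but nothing available here connects either difference to the lower number.

Still open, from the compounds shown here alone, is whether the lower number belongs to hydroxymethyl alone or extends to close relatives at this aromatic carbon, such as methoxymethyl, aminomethyl or a carboxylic acid, which would separate the effect of the free hydroxyl from that of the small chain. Also open, going by these compounds, is whether the same step appears when the butyl chain on the shared core is replaced by a different chain.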